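A few compounds are considered here, and "the series" means these few. Any claim that something is new, unique, unknown or untested is made for them only; others in the source may bear on it.

Two compounds carry the shared core here. Compound 1 `CC1CCc2sc(NC(=O)CN3CCN(c4ccc(F)cc4)CC3)nc2C1` gives 26 nM in an assay on isolated protein for inhibition of long-chain fatty acid transport protein 1 (Homo sapiens), read by scintillation counting, with a stated time of 20 min; a lower number here means a stronger inhibitor, a higher number a weaker inhibitor. Compound 2 `O=C(CN1CCN(c2nccs2)CC1)Nc1nc2c(s1)CCCC2` gives 520 nM in this assay, the highest of the two numbers, a step beyond the scatter above compound 1.

Compound 3 `O=C(CN1CCN(c2ccc(F)cc2)CC1)Nc1nc2c(s1)CCCC2` is not yet measured in this assay. It differs from compound 2 in one place: 4-fluorophenyl in place of 1,3-thiazol-2-yl on an amine nitrogen in a ring, the exchange being made on an amine nitrogen in a ring of a six-membered non-aromatic ring with two nitrogens.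

Within the data shown here, no measured pair isolates this exchange, so the size of the step rests on what the two values show. The expected direction is toward a lower number, with a step well beyond the scatter, because compound 1, which also carries the 4-fluorophenyl, gives 26 nM. The step from compound 2 to compound 3 is estimated as an 8.7-fold lower number from compound 2 to compound 3 (0.94 log units; beyond the scatter). Compound 3 is therefore expected to give about 60 nM, within a range from 20 nM to 200 nM.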

Compound 3, half-maximal inhibitory concentration: 77 nM
Compound 3: the middle estimate sits 1.3-fold (0.11 log units) below what was measured; the range from low to high includes it.
By their numbers in this assay, from the lowest: compound 1; then compound 3; then compound 2.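

In this assay, the exchange of 1,3-thiazol-2-yl for 4-fluorophenyl on an amine nitrogen in a ring now stands as a measured step on its own, with the rest of the molecule held fixed: a 6.8-fold lower number from compound 2 to compound 3 (0.83 log units; beyond the scatter). The result also brings a second single change into view, since hydrogen in place of methyl on a saturated ring carbon gives a 3.0-fold higher number from compound 1 to compound 3 (0.47 log units; beyond the scatter), so this ring carbon also bears on the number. Nothing measured here accounts for either step.

On these data alone, it remains open how a phenyl without the fluorine, or a pyridin-2-yl, would stand on the same ring nitrogen, so the part played by the fluorine cannot be separated from that of the ring carrying it. An ethyl on the saturated ring carbon also remains an open case.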